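Sulfonamide nitrogen substituents on a shared thiourea core

The source may report more compounds than this note shows. Statements on the series, on what has been measured and on what is new or still open speak of the compounds shown alone.

Compound 2 `N=C(N)NS(=O)(=O)c1ccc(N/C(S)=N\c2ccnc3cc(C(F)(F)F)ccc23)cc1` gives the lower of the two numbers in a functional assay on LoVo cells (Homo sapiens) for antiproliferative activity, read by sulforhodamine B assay, with a stated time of 48 h (a lower number here means a stronger inhibitor, a higher number a weaker inhibitor), at 23900 nM; compound 1 `CC(=O)NS(=O)(=O)c1ccc(N/C(S)=N\c2ccnc3cc(C(F)(F)F)ccc23)cc1` gives 30000 nM, and the gap is within the scatter. Compound 3 `Cc1cc(NS(=O)(=O)c2ccc(N/C(S)=N\c3ccnc4cc(C(F)(F)F)ccc34)cc2)on1` was reported in this assay as "not active" (no number reported), with no number given. Compound 4 `Cc1ccnc(NS(=O)(=O)c2ccc(N/C(S)=N\c3ccnc4cc(C(F)(F)F)ccc34)cc2)n1` differs from compound 2 by a group of 7 heavy atoms (5 carbon, 2 nitrogen; one six-membered aromatic ring with 2 hetero atoms) in place of a group of 3 heavy atoms (1 carbon, 2 nitrogen; no ring), on a sulfonamide nitrogen. Within the data shown here, the only measured step at this position, a 1.3-fold lower number from compound 1 to compound 2 (0.10 log units; within the scatter), lies within the scatter, while compound 3 carries a heteroaryl on the same nitrogen and shows no measurable activity. Compound 4 is therefore expected to be weak or inactive, with an expected step of a 1.9-fold higher number from compound 2 to compound 4 (0.27 log units; within the scatter). For compound 4 the estimate in this assay is 45000 nM, ranging from 15000 nM to 150000 nM.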

Compound 4, half-maximal inhibitory concentration: 31000 nM
Compound 4: the middle estimate sits 1.5-fold (0.16 log units) above what was measured; measured number inside the range.
By their numbers in this assay, from the lowest: compounds 2, 1 and 4 (each within the scatter of the next).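

In this assay, 4-methylpyrimidin-2-yl on the sulfonamide nitrogen gives a 1.3-fold higher number from compound 2 to compound 4 (0.11 log units; within the scatter) and a 1.0-fold higher number from compound 1 to compound 4 (0.01 log units; within the scatter), so a ring-bearing group here gives a number within the scatter of both ringless groups. Compound 3 also carries a heteroaryl on this nitrogen and was reported as not active, whereas compound 4 gives 31000 nM, so a heteroaryl at this position does not by itself remove measurable activity.

Still open, on these data alone, is whether a primary amine or a longer alkyl chain on this nitrogen would move the number beyond the scatter. Nothing available accounts for the difference between compound 3 and compound 4.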